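Swapping a Trifluoromethyl Oxadiazole for a tert-Butoxycarbonyl Group

The compounds below may be only part of what the source reports. "The series", "measured", "known", "first", "only" and "open" are said of these compounds alone.

Compound 1 `CCN(CC)S(=O)(=O)c1ccc(S(=O)(=O)N2CCC[C@@H](C(=O)N3CCN(c4nc(C(F)(F)F)no4)CC3)C2)cc1` gives the lowest of the two plain numbers here: in a functional assay on MIA PaCa-2 cells (Homo sapiens) for inhibition, read by MTT assay, with a stated time of 7 days (on this read-out lower numbers stand for stronger inhibition and higher numbers for weaker inhibition), compound 1 reaches 600 nM. Its nearest neighbour, compound 2 `CCN(CC)C(=O)[C@@H]1CCCN(S(=O)(=O)c2ccc(S(=O)(=O)N(CC)CC)cc2)C1`, gives 6400 nM in this assay, a higher number that lies beyond the usual scatter. Compound 3 `CCOC(=O)N1CCC[C@@H](S(=O)(=O)c2ccc(S(=O)(=O)N(CC)CC)cc2)C1` gives only a limit of the assay, > 30000 nM, and not a number.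

Compound 4 `CCN(CC)S(=O)(=O)c1ccc(S(=O)(=O)N2CCC[C@@H](C(=O)N3CCN(C(=O)OC(C)(C)C)CC3)C2)cc1` differs from compound 1 in one place: tert-butoxycarbonyl in place of 3-(trifluoromethyl)-1,2,4-oxadiazol-5-yl on an amine nitrogen in a ring. For the measured compounds named here, no measured pair shows this exact change, so the size of the step is uncertain. A moderate loss of potency is expected, with the step from compound 1 to compound 4 estimated at a 3.3-fold higher number from compound 1 to compound 4 (0.52 log units; beyond the scatter). Compound 4 is therefore expected to give about 2000 nM, somewhere between 600 nM and 8000 nM.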

Compound 4, half-maximal inhibitory concentration: 70 nM
Compound 4: middle estimate off by 29-fold (1.46 log units), on the high side; the whole stated range lies above it.
By their numbers in this assay, from the lowest: compound 4; then compound 1; then compound 2. At a limit, above all of these: compound 3.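

Replacing the 3-(trifluoromethyl)-1,2,4-oxadiazol-5-yl group with tert-butoxycarbonyl on this amine nitrogen gives an 8.6-fold lower number from compound 1 to compound 4 (0.93 log units; beyond the scatter) in this assay. This is the first step shown at this position, and it reveals that the five-membered aromatic ring is not required for activity in this assay. A group with no ring at this position gives the lowest number in the set.

As far as these compounds go, whether an acetyl group, a methoxycarbonyl group or the free amine would perform as well at this nitrogen remains open. Nothing shown here explains why tert-butoxycarbonyl gives the lower number.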